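The source may report more compounds than this note shows. Statements on the series, on what has been measured and on what is new or still open speak of the compounds shown alone.

The measurement here is an assay on CHO cells for inhibition of Glucagon receptor (Homo sapiens), tested at 20 uM; on this read-out lower numbers stand for less inhibition and higher numbers for more inhibition at the one concentration tested (going by the name of the read-out). Three compounds that share one core have been run through it. Compound 1, `CCCCCc1c(C(C)C)nc(C(C)C)c(CO)c1-c1ccc(CC)cc1`, gives 42% in this assay. Compound 2, `CCCCCc1c(C(C)C)nc(C(C)C)c(CO)c1-c1ccc2ccccc2c1`, gives 16%, and compound 3, `CCCCCc1c(C(C)C)nc(C(C)C)c(CO)c1-c1ccc2c(c1)CCCC2`, gives 37%. On these three numbers compound 1 stands at the top, but the gap to compound 3 lies within the usual scatter of repeated measurements, so those two cannot be told apart; only the gap to compound 2 lies beyond the scatter, so compound 2 shows clearly less inhibition than compound 1.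

The next compound, compound 4, is `CCCCCc1c(C(C)C)nc(C(C)C)c(CO)c1-c1ccc(Cl)cc1Cl`. Compared with compound 1 the change is 2,4-dichlorophenyl in place of 4-ethylphenyl on an aromatic carbon. For the measured compounds named here, no pair of measured compounds differs in just this way, so the size of the step is open. The expected step from compound 1 to compound 4 is a number 7 percentage points lower from compound 1 to compound 4 (within the scatter), that is, a small drop that may well sit within the scatter. The estimate for compound 4 is 35%, with a range from 10% to 60%.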

Compound 4, a percentage reported as inhibition, at one concentration (the size of the read-out at that concentration, not a potency): 8%
For compound 4 the middle estimate is 27 percentage points above the measured one; measured number outside the range, below it.
By their numbers in this assay, from the lowest: compounds 4 and 2 (each within the scatter of the next); then compounds 3 and 1 (each within the scatter of the next).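

This result shows that the group on this carbon, opposite the ring nitrogen, can matter a great deal even when its size by count stays the same: 4-ethylphenyl and 2,4-dichlorophenyl have the same number of heavy atoms and neither has a hydrogen-bond donor or acceptor, yet the swap gives a number 34 percentage points lower from compound 1 to compound 4 (beyond the scatter) in this assay. Until now, only the naphthalene-free comparison of values pointed to a clear loss at this position, and compound 4 at 8% now lies within the scatter of compound 2 at 16%, so two quite different aryl groups end up in the same low range. Nothing measured here bears on the cause of this drop.

The swap removes the ethyl group and brings in two chlorines in one move, so the compounds shown cannot say whether the loss follows from losing the ethyl group, from the chlorine at the 2 position of the name, or from the one at the 4 position. As far as these compounds go, a 4-chlorophenyl or a 2-chloro-4-ethylphenyl group at this carbon would pull these apart, and how far the number moves with such groups remains open.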